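A few compounds are considered here, and "the series" means these few. Any claim that something is new, unique, unknown or untested is made for them only; others in the source may bear on it.

Of the compounds shown here, three have so far been tested in a functional assay on Hep 3B2 cells (Homo sapiens) for antiproliferative activity, read by MTT assay, with a stated time of 24 h, tested at 100 ug/mL; on this read-out lower numbers stand for a weaker effect and higher numbers for a stronger effect at the one concentration tested. Compound 1 `Cc1ccc2nc(C(=O)Nc3c(F)cc(-c4cccc(F)c4)cc3F)c(C)c(O)c2c1` gives 68.3%, and compound 3 `Cc1ccc2nc(C(=O)Nc3c(F)cc(-c4cccc(F)c4)cc3F)c(C)c(C(=O)O)c2c1`, which differs from it only by carboxy in place of hydroxy on an aromatic carbon, gives 75.2%; that change produced a step of a number 6.9 percentage points higher from compound 1 to compound 3 (within the scatter). Compound 2 `COc1ccc2nc(C(=O)Nc3ccc(-c4ccccc4)cc3)c(C)c(O)c2c1` gives 79.3%; how its core differs from that of compound 1 is not broken down here. Compound 4 `COc1ccc2nc(C(=O)Nc3ccc(-c4ccccc4)cc3)c(C)c(C(=O)O)c2c1` is the untested counterpart of compound 2, carrying the same change, (carboxy in place of hydroxy on an aromatic carbon). The surroundings of the change are described in the same words in both pairs, so it counts as the same kind of change. Because a number 6.9 percentage points higher from compound 1 to compound 3 (within the scatter) stayed within the scatter, a step of similar size is expected here, namely a number 3.7 percentage points higher from compound 2 to compound 4 (within the scatter). Compound 4 is therefore estimated to give 83%, most likely between 72% and 93%.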

Compound 4, a percentage reported as inhibition, at one concentration (the size of the read-out at that concentration, not a potency): 72.5%
Compound 4: the middle estimate sits 10.5 percentage points above what was measured; the measured number falls inside the stated range.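

In this assay, carboxy in place of hydroxy on an aromatic carbon now comes with a number 6.8 percentage points lower from compound 2 to compound 4 (within the scatter). Set beside the earlier step, the two results cannot be told apart: the same change on two cores in this assay, a number 6.9 percentage points higher (within the scatter) from compound 1 to compound 3 and a number 6.8 percentage points lower (within the scatter) from compound 2 to compound 4, 13.7 percentage points apart, within the scatter of two such steps. On these two cores, the change therefore leaves the read-out within the usual scatter, but this does not establish a real rise or fall, and a reading at one concentration says nothing about potency.

The compounds shown leave open how an amine or an amide on that same aromatic carbon would compare with hydroxy and carboxy. They also leave open whether the change would behave the same way on other cores.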